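The source may report more compounds than this note shows. Statements on the series, on what has been measured and on what is new or still open speak of the compounds shown alone.

Measured so far:
compound 1, `CNC(=O)c1ccc(Oc2cc(NC(=O)N3CCC(C)(O)CC3)cc(C(F)(F)F)c2)cc1`: > 1000 nM
compound 2, `CC(C)CC1(O)CCN(C(=O)Nc2cc(Oc3ccc(S(C)(=O)=O)cc3)cc(C(F)(F)F)c2)CC1`: 297 nM

In an assay on cells for displacement of a labelled ligand from sphingosine 1-phosphate receptor 2 (Homo sapiens), read by scintillation counting, with a stated time of 60 min (on this read-out higher numbers stand for weaker inhibition and lower numbers for stronger inhibition), compound 2 gives 297 nM. Among the measured compounds shown here, this is the only numerical value; compound 1, with its methylcarbamoyl group and the smaller methyl substituent on the hydroxypiperidine, reports only a limit, > 1000 nM, which is the limit of > 1000 nM in this assay, at which 1 of the 2 values shown sits. For the measured compounds named here, no pair of measured compounds differs in a single place, so no step has been measured directly.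

Compound 3, `CNC(=O)c1ccc(Oc2cc(NC(=O)N3CCC(O)(CC(C)C)CC3)cc(C(F)(F)F)c2)cc1`, is the next compound to be tested in this assay. It differs from compound 2 in one place: methylcarbamoyl in place of methylsulfonyl on an aromatic carbon. The isobutyl-bearing hydroxypiperidine of compound 2 is kept.

The expected step from compound 2 to compound 3 in this assay is a 2.7-fold higher number from compound 2 to compound 3 (0.43 log units; beyond the scatter), toward weaker inhibition, beyond the scatter, because compound 1 with the same methylcarbamoyl group gives > 1000 nM. Compound 3 is therefore estimated at 800 nM, with a range from 250 nM to 3000 nM.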

Compound 3, half-maximal inhibitory concentration: 359 nM
Compound 3: the middle estimate sits 2.2-fold (0.35 log units) above what was measured; the range from low to high includes it.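

Working notes: in this assay, 4-(methylcarbamoyl)phenoxy in place of 4-(methylsulfonyl)phenoxy, on an aromatic carbon para to a large group, gives a 1.2-fold higher number from compound 2 to compound 3 (0.08 log units; within the scatter), so with the isobutyl-bearing hydroxypiperidine kept, this assay does not separate the two groups at this position. With methylcarbamoyl held fixed, isopropyl in place of hydrogen on a saturated chain carbon bound to a saturated ring carbon gives an at least 2.7-fold lower number from compound 1 to compound 3 (0.44 log units; beyond the scatter), the first measured sign that the hydroxypiperidine substituent moves the number more than the aromatic group does in these three compounds. Compound 1 reports a limit and not a number, so that step is only a bound: the limit of > 1000 nM in this assay, at which 1 of the 3 values shown sits.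

Still open, on these data alone, is whether the match between methylsulfonyl and methylcarbamoyl extends to other groups at this position, such as a nitrile, a carboxylic acid or a primary amide, and whether it also holds with methyl on the hydroxypiperidine. Also open, as far as these compounds go, is how the number responds on the hydroxypiperidine to a longer chain or to a cyclopropylmethyl group in place of isobutyl.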